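This account rests on a few compounds, and the source may have more. Where it says the series, first, only, none or still open, it means among the compounds named here.

Compound 1 `Nc1nc(NCCNc2ncc(-c3ncc[nH]3)c(-c3ccc(C(F)(F)F)cc3)n2)ccc1[N+](=O)[O-]` is the point of departure. In an ADME assay on microsomes from liver (Canis lupus familiaris) for metabolic stability (a lower number here means that the compound disappears faster, a higher number that the compound lasts longer), compound 1 gives > 0.5 h, which is a limit of the assay rather than a number. Compound 2 `Nc1nc(NCCNc2ncc(-c3ncc[nH]3)c(-c3ccc(F)cc3F)n2)ccc1[N+](=O)[O-]` carries 2,4-difluorophenyl in place of 4-(trifluoromethyl)phenyl, and in this assay compound 2 gives > 0.5 h, again a limit. Compound 3 `Nc1nc(NCCNc2ncc(-c3ncc[nH]3)c(-c3ccc(F)cc3Br)n2)ccc1[N+](=O)[O-]` carries 2-bromo-4-fluorophenyl, and in this assay compound 3 gives > 0.5 h, also a limit. The steps a step that the two limits leave unreadable from compound 1 to compound 2, a step that the two limits leave unreadable from compound 1 to compound 3 and a step that the two limits leave unreadable from compound 2 to compound 3 therefore have no readable size. Compound 4 `Nc1nc(NCCNc2ncc(-c3ncc[nH]3)c(-c3cc(F)c(Cl)cc3Cl)n2)ccc1[N+](=O)[O-]` differs from compound 1 as follows: 2,4-dichloro-5-fluorophenyl in place of 4-(trifluoromethyl)phenyl on an aromatic carbon. The steps to compound 2 and compound 3 bear on this change of the same phenyl group, yet none of them can be read because of the limit of > 0.5 h in this assay, at which 3 of the 3 values shown sit. No step beyond the scatter can be read from them, and compound 4 is expected to reach at or past the same limit. Compound 4 is estimated at 1 h, with a range from 0.5 h to 3 h. This corresponds to an expected step that the limit leaves unreadable from compound 1 to compound 4.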

Compound 4, half-life: > 0.5 h
Compound 4: a limit, no number; the forecaster's own chance of this, stated with the estimate: 70%; the middle value lies beyond the limit too.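

No new step can be read from compound 4 to compound 1, compound 2 or compound 3 in this assay, because each value is a limit and not a number: the limit of > 0.5 h in this assay, at which 4 of the 4 values shown sit.

The compounds shown leave open whether these four phenyl groups differ at all in this assay.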